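Swapping an Anilide for a Pyrazolylamine on the Shared Core

This account rests on a few compounds, and the source may have more. Where it says the series, first, only, none or still open, it means among the compounds named here.

Compound 2 `O=C(Nc1ccccc1)c1cnc(NCc2c(F)ccc3c2CCO3)n2cnnc12` was tested in an ADME assay on microsomes from liver (Homo sapiens) for metabolic stability, read by LC-MS, using NADPH, with stated times of 5 min and 30 min, tested at 1 uM (on this read-out higher numbers stand for fast clearance and lower numbers for slow clearance), and gives 14 mL.min-1.g-1. Within the data shown here, it is one of only two plain numbers reported in this assay: the other belongs to compound 3 `O=C1CCCN1c1cnc(NCc2c(F)ccc3c2CCO3)c2cn[nH]c(=O)c12`, which gives 23 mL.min-1.g-1, a value within the scatter of that of compound 2. Compound 1 `CNC(=O)c1cc(-c2cnc(NCc3c(F)ccc4c3CCO4)c3cn[nH]c(=O)c23)n(C)n1` gives < 3 mL.min-1.g-1, which is a limit of the assay, (the limit of < 3 mL.min-1.g-1 in this assay, at which 1 of the 3 values shown sits), and not a number. Among the measured compounds shown here, the single measured step between compounds differing in one place is an at least 7.6-fold higher number from compound 1 to compound 3 (0.88 log units; beyond the scatter), on the core of compound 1, where 2-oxopyrrolidin-1-yl replaces 1-methyl-3-(methylcarbamoyl)-1H-pyrazol-5-yl on an aromatic carbon.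

Compound 4 `CN(c1ccn(C)n1)c1cnc(NCc2c(F)ccc3c2CCO3)n2cnnc12` keeps the core of compound 2 and differs from it in one place: methyl(1-methyl-1H-pyrazol-3-yl)amino in place of phenylcarbamoyl on an aromatic carbon. The new group sits on an aromatic carbon of a six-membered aromatic ring with 2 nitrogen, part of a fused or bridged system of two rings, ortho to a fused ring and para to a large group. For the measured compounds named here, no measured step concerns this exchange; the only one available, an at least 7.6-fold higher number from compound 1 to compound 3 (0.88 log units; beyond the scatter), involves other groups on another core and offers no guide. The step expected for compound 4 is therefore none beyond the scatter, a 1.3-fold higher number from compound 2 to compound 4 (0.11 log units; within the scatter). The estimate for compound 4 in this assay is 18 mL.min-1.g-1, with a range from 7 mL.min-1.g-1 to 45 mL.min-1.g-1.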

Compound 4, intrinsic clearance in microsomes: 11 mL.min-1.g-1
Estimate against measurement, compound 4: 1.6-fold (0.21 log units) above; the measured number falls inside the stated range.
By their numbers in this assay, from the lowest: compounds 4, 2 and 3 (each within the scatter of the next, the first and the last beyond it). At a limit, below all of these: compound 1.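

In this assay, the exchange on the shared core gives a 1.3-fold lower number from compound 2 to compound 4 (0.10 log units; within the scatter), so on this aromatic carbon of a six-membered aromatic ring with 2 nitrogen, para to a large group, methyl(1-methyl-1H-pyrazol-3-yl)amino takes the place of phenylcarbamoyl with no change beyond the scatter. Among these compounds, this is the first measured step at this position, and it shows that the read-out stays within the scatter when a six-membered aromatic ring of carbon only and a hydrogen-bond donor leave and a five-membered aromatic ring with 2 hetero atoms and no hydrogen-bond donor enters. No measured property among the data shown bears on this result.

From the compounds shown here alone, with only these two groups read at this position, it remains open whether a group without a ring, such as a plain dimethylamino, or a carboxylic acid would also stay within the scatter of them. Also open, going by these compounds, is how the 1-methyl-3-(methylcarbamoyl)-1H-pyrazol-5-yl group of compound 1 would read on the core of compound 2 and compound 4.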